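A few compounds are considered here, and "the series" means these few. Any claim that something is new, unique, unknown or untested is made for them only; others in the source may bear on it.

Measured so far:
compound 1, `CCCCOC(=O)OCC1OC(n2cc(C)c(=O)[nH]c2=O)CC1N=[N+]=[N-]`: 0.15 h
compound 2, `Cc1cn(C2CC(N=[N+]=[N-])C(COC(=O)CCCC(=O)O)O2)c(=O)[nH]c1=O`: 30 h

Within the data shown here, in an ADME assay on the whole organism (serum) with Homo sapiens as the target (a higher number here means that the compound lasts longer, a lower number that the compound disappears faster), compound 2 gives the higher of the two numbers; compound 1 sits far lower, and the only recorded step, a 200-fold higher number from compound 1 to compound 2 (2.30 log units; beyond the scatter), is the change from compound 1 to that value. Compound 3, `Cc1cn(C2CC(N=[N+]=[N-])C(COC(=O)CCCC(=O)OC(C)(C)C)O2)c(=O)[nH]c1=O`, differs from compound 2 by tert-butyl in place of hydrogen on an oxygen next to a carbonyl group. Among the measured compounds shown here, no measured step covers this exact change; the one step known shows that altering the end of this side chain can shift this assay strongly. Compound 3 is therefore expected to give a lower number, estimated as 2 h (range 0.3 h to 15 h). The expected step is a 15-fold lower number from compound 2 to compound 3 (1.18 log units; beyond the scatter).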

Compound 3, half-life: 0.55 h
Compound 3: the middle estimate sits 3.6-fold (0.56 log units) above what was measured, within the range that was stated.
By their numbers in this assay, from the lowest: compound 1; then compound 3; then compound 2.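

In this assay, the step of a 55-fold lower number from compound 2 to compound 3 (1.74 log units; beyond the scatter) shows that most of the long half-life is lost when the free carboxy end becomes tert-butoxycarbonyl. The step of a 3.7-fold higher number from compound 1 to compound 3 (0.56 log units; beyond the scatter) shows that the capped chain keeps only a modest gain over the butoxy group, so most of the gap between compound 1 and compound 2 goes with the hydrogen on this oxygen, not with the chain alone. Nothing available explains why this change has such an effect.

Open, on these data alone, is whether, in this assay, a methyl ester or a primary amide at this chain end would stand closer to compound 2 or to compound 3.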